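A Fluorine for a Methoxy on the Ring Nitrogen Aryl

The source may report more compounds than this note shows. Statements on the series, on what has been measured and on what is new or still open speak of the compounds shown alone.

Compound 1 `COc1ccc(OC)c(N2C(=O)CSC2c2cccc(C(=O)NCCCCc3ccccc3)c2)c1` is tested in a functional assay on MG-63 cells (Homo sapiens) for inhibition, read by CCK-8 assay, with a stated time of 72 h, tested at 1 uM (a higher number here means more inhibition at the concentration tested (going by the name of the read-out), a lower number less inhibition), and gives 92%. Compound 2 `CCOc1ccccc1N1C(=O)C(C)SC1c1cccc(C(=O)NCCCCc2ccccc2)c1` gives 92% in this assay, so the two stand level within the scatter and together at the top of the three values; compound 3 `COc1ccccc1N1C(=O)CSC1C(=O)NCCCCc1ccccc1` gives 60%, a lower value beyond the scatter. The next member is compound 4 `COc1c(F)cccc1N1C(=O)CSC1c1cccc(C(=O)NCCCCc2ccccc2)c1`, which differs from compound 1 by 3-fluoro-2-methoxyphenyl in place of 2,5-dimethoxyphenyl on an amide-type nitrogen in a ring. For the measured compounds named here, no measured pair shows this exact change, but compound 1 and compound 2 show that varying the group on the ring nitrogen leaves the number unchanged within the scatter. Compound 4 is therefore expected to give a step of a number 4 percentage points lower from compound 1 to compound 4 (within the scatter), no change beyond the scatter. The estimate for compound 4 is 88%, between 70% and 98%.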

Compound 4, a percentage reported as inhibition, at one concentration (the size of the read-out at that concentration, not a potency): 0%
Beside the measured number, compound 4's estimate is 88 percentage points above it; the measured number lies below the stated range.
By their numbers in this assay, from the lowest: compound 4; then compound 3; then compounds 1 and 2 (each within the scatter of the next).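

In this assay, 3-fluoro-2-methoxyphenyl in place of 2,5-dimethoxyphenyl on the amide-type nitrogen in the ring gives a step of a number 92 percentage points lower from compound 1 to compound 4 (beyond the scatter). For the compounds shown here, this is the first step that can be read at this position, and it shows that this single change, with the rest of the molecule the same, can take the read-out from the top of the series to its bottom. Nothing measured here accounts for the step. The compounds shown leave open whether the step follows the departure of one methoxy or the arrival of the fluorine. From the compounds shown here alone, how a phenyl carrying chlorine, a hydroxyl or an amine on this nitrogen would read also remains open.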